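Cytotoxicity notes: bromo to (pyridin-2-yl)methoxy on the core

This account rests on a few compounds, and the source may have more. Where it says the series, first, only, none or still open, it means among the compounds named here.

Compound 1 `Cc1nnsc1C(=O)Nc1nc2ccccc2o1`: 19600 nM
Compound 2 `Cc1nnsc1C(=O)Nc1nc2c(Br)cccc2o1`: 10600 nM
Compound 3 `O=C(Nc1nc2ccccc2o1)c1ccco1`: limit, > 100000 nM

In an ADME assay on HEK293 cells (Homo sapiens) for cytotoxicity, read by CCK-8 assay, with a stated time of 48 h (on this read-out lower numbers stand for stronger inhibition and higher numbers for weaker inhibition), compound 2 gives 10600 nM, the lowest of the two numbers given as numbers, with compound 1 nearest at 19600 nM; the two sit within the scatter of each other. Compound 3 gives only a limit of the assay, > 100000 nM, and one of the three values given is such a limit (the limit of > 100000 nM in this assay, at which 1 of the 3 values shown sits).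

Compound 4 `Cc1nnsc1C(=O)Nc1nc2c(OCc3ccccn3)cccc2o1` is not yet measured. It differs from compound 2 in one place: (pyridin-2-yl)methoxy in place of bromo on an aromatic carbon.

Going by the values given here, of the measured steps, only the one that touches the same aromatic carbon bears on this change: a 1.8-fold lower number from compound 1 to compound 2 (0.27 log units; within the scatter). The other measured step, an at least 5.1-fold higher number from compound 1 to compound 3 (0.70 log units; beyond the scatter), concerns the carbonyl side and not the position changed here. Among the compounds with values here, no measured step exchanges bromo for an ether-linked group, so the size of the step from compound 2 to compound 4 in this assay is open. Given that the bromo-for-hydrogen change stayed within the scatter, the step of a 1.4-fold higher number from compound 2 to compound 4 (0.15 log units; within the scatter) is expected to be small, with wide uncertainty. Compound 4 is therefore estimated at 15000 nM, within 4000 nM to 60000 nM.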

Compound 4, half-maximal inhibitory concentration: 61800 nM
Beside the measured number, compound 4's estimate is 4.1-fold (0.61 log units) below it; measured number above the stated range.
By their numbers in this assay, from the lowest: compounds 2 and 1 (each within the scatter of the next); then compound 4. At a limit, above all of these: compound 3.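

In this assay this aromatic carbon proves able to shift the number: bromo in place of hydrogen stayed within the scatter, whereas (pyridin-2-yl)methoxy in place of bromo moves it beyond the scatter (a 5.8-fold higher number from compound 2 to compound 4 (0.77 log units; beyond the scatter)). The same group also lies beyond the scatter when read against hydrogen (a 3.2-fold higher number from compound 1 to compound 4 (0.50 log units; beyond the scatter)), so the shift holds against both earlier groups on this carbon. Weaker inhibition of these cells had until now been seen only through the carbonyl side, in compound 3, whose value is a limit.

Open, on these data alone, is which part of the (pyridin-2-yl)methoxy group carries the step; a plain methoxy, a benzyloxy or an amine on this carbon would separate the ether link from the ring. The values shown offer no measured reason for either step.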